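The compounds below may be only part of what the source reports. "The series", "measured", "known", "first", "only" and "open" are said of these compounds alone.

Compound 1 `S=C(N/N=C/c1ccc2ccccc2n1)Nc1ccc(Cl)cc1` is measured in a functional assay on HL-60 cells (Homo sapiens) for antiproliferative activity, read by sulforhodamine B assay, with a stated time of 72 h; a lower number here means a stronger inhibitor, a higher number a weaker inhibitor. In this assay compound 1 gives only a limit of the assay, > 100000 nM. Compound 2 `Fc1ccc(NC(=S)N/N=C/c2ccc3ccccc3n2)cc1` gives 17000 nM in this assay. The change from compound 1 to compound 2, (fluoro in place of chloro on an aromatic carbon), made a step of an at least 5.8-fold lower number from compound 1 to compound 2 (0.76 log units; beyond the scatter). Compound 3 `S=C(N/N=C/c1ccc2ccccc2n1)Nc1cccc(Cl)c1` gives 28800 nM in this assay. Its core differs from that of compound 1 by 3-chlorophenyl in place of 4-chlorophenyl on an amide-type nitrogen, a step of an at least 3.4-fold lower number from compound 1 to compound 3 (0.54 log units; beyond the scatter); against compound 2 the step is a 1.7-fold higher number from compound 2 to compound 3 (0.23 log units; within the scatter). Compound 4 `Fc1cccc(NC(=S)N/N=C/c2ccc3ccccc3n2)c1` is not yet measured; it differs from compound 3 by fluoro in place of chloro on an aromatic carbon, the same kind of change as from compound 1 to compound 2, here meta to a large group rather than para to a large group. Since the earlier step of an at least 5.8-fold lower number from compound 1 to compound 2 (0.76 log units; beyond the scatter) rests on (the limit of > 100000 nM in this assay, at which 1 of the 3 values shown sits), a smaller lowering is expected from compound 3 to compound 4, a 1.9-fold lower number from compound 3 to compound 4 (0.28 log units; within the scatter). For compound 4 the expected value is 15000 nM, between 5000 nM and 50000 nM.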

Compound 4, half-maximal inhibitory concentration: 43800 nM
For compound 4 the middle estimate is 2.9-fold (0.47 log units) below the measured one; the range from low to high includes it.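

In this assay, fluoro in place of chloro on an aromatic carbon does not carry as one step from core to core: the same change on two cores in this assay, an at least 5.8-fold lower number (0.76 log units; beyond the scatter) from compound 1 to compound 2 and a 1.5-fold higher number (0.18 log units; within the scatter) from compound 3 to compound 4, at least 8.9-fold (0.95 log units) apart, beyond the scatter of two such steps. The size of the earlier step is only a bound, since compound 1 sits at a limit of the assay: the limit of > 100000 nM in this assay, at which 1 of the 4 values shown sits. On the second core the change gives (a 1.5-fold higher number from compound 3 to compound 4 (0.18 log units; within the scatter)), and the other comparisons are (a 2.6-fold higher number from compound 2 to compound 4 (0.41 log units; beyond the scatter)) and (an at least 2.2-fold lower number from compound 1 to compound 4 (0.35 log units; beyond the scatter)); these show that the step differs between the two cores, not why it differs.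

Open, as far as these compounds go, is whether a methoxy group, an amine or a carboxylic acid in place of the halogen would follow either core. Two pairs also leave open how far this difference extends beyond these compounds.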